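The compounds below may be only part of what the source reports. "The series", "measured", "known", "first", "only" and "open" are said of these compounds alone.

Measured so far:
compound 1 `C=C(Br)C(=O)Nc1cccc(-c2cn3nc(-c4ccc(OCC)cc4)sc3n2)c1` — 1400 nM
compound 2 `C=C(Br)C(=O)Nc1cccc(-c2cn3c(-c4ccc(OC)cc4)csc3n2)c1` — 500 nM

In a functional assay on CCRF-CEM cells (Homo sapiens) for inhibition, read by cell counting, with a stated time of 3 days (a higher number here means a weaker inhibitor, a lower number a stronger inhibitor), compound 1 gives 1400 nM, the highest of the two numbers. The nearest neighbour is compound 2, which gives 500 nM in this assay, a lower number by a margin beyond the usual scatter. Among the compounds with values here, compound 2 also carries a different arrangement of the fused core, so the two values show only that compound 2 is the stronger inhibitor of the pair, not which feature accounts for that.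

Compound 3 `C=C(Br)C(=O)Nc1cccc(-c2cn3nc(Cc4ccc(OC)cc4)sc3n2)c1` has not yet been measured. It differs from compound 1 as follows: 4-methoxybenzyl in place of 4-ethoxyphenyl on an aromatic carbon. The same atoms are rearranged, so the attached group keeps its size while the aromatic ring is now carried on the benzyl linker rather than joined directly to the core, and the alkoxy chain is shortened by the same amount. Within the data shown here, no measured pair shows a change of this kind, so there is no precedent to lean on. The step is expected to be small, most likely a modest weakening, possibly none beyond the scatter; the expected change is a 1.6-fold higher number from compound 1 to compound 3 (0.20 log units; within the scatter). Compound 3 is therefore estimated at 2200 nM, with a range from 700 nM to 7000 nM.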

Compound 3, half-maximal inhibitory concentration: 2300 nM
Compound 3: the middle estimate sits 1.0-fold (0.02 log units) below what was measured; the range from low to high includes it.
By their numbers in this assay, from the lowest: compound 2; then compounds 1 and 3 (each within the scatter of the next).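

In this assay, within the data shown here, the first step that changes one place only gives a 1.6-fold higher number from compound 1 to compound 3 (0.22 log units; within the scatter) for 4-methoxybenzyl in place of 4-ethoxyphenyl, so compounds 1 and 3 cannot be told apart. On this aromatic carbon, next to the ring nitrogen and the ring sulfur, the aromatic ring can therefore be carried on a benzyl linker instead of being joined directly to the core, with the alkoxy chain shortened at the same time, and the number stays within the scatter. No accompanying measurement bears on this result, which stands as an observation about these two compounds only.

Open, from the compounds shown here alone, is how the benzyl linker and the shortened alkoxy chain count on their own, as this single swap alters both together, and whether either would behave the same way on the core of compound 2. Also open, going by these compounds, is how this position responds to groups of another kind, such as an amine or a carboxylic acid, or to a longer chain on the aromatic ring.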